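Chloro for Bromo on a Fluorophenyl Chalcone Core

The source may report more compounds than this note shows. Statements on the series, on what has been measured and on what is new or still open speak of the compounds shown alone.

Measured compounds:
compound 1, `Cc1ccc(C(=O)/C=C/c2cccc(Br)c2Oc2c([N+](=O)[O-])cc(C(F)(F)F)cc2[N+](=O)[O-])cc1`, 0.55 ug/mL
compound 2, `Cc1ccc(C(=O)/C=C/c2cccc(Cl)c2Oc2c([N+](=O)[O-])cc(C(F)(F)F)cc2[N+](=O)[O-])cc1`, 0.03 ug/mL
compound 3, `O=C(/C=C/c1cccc(Br)c1Oc1c([N+](=O)[O-])cc(C(F)(F)F)cc1[N+](=O)[O-])c1ccc(F)cc1`, 6.01 ug/mL

Of the compounds shown here, three have been tested in a functional assay on MCF7 cells (Homo sapiens) for antiproliferative activity, read by MTT assay, with a stated time of 48 h; a lower number here means a stronger inhibitor, a higher number a weaker inhibitor. Compound 2 gives the lowest number of the three. The step of an 18-fold lower number from compound 1 to compound 2 (1.26 log units; beyond the scatter) comes from chloro in place of bromo on an aromatic carbon. The step of an 11-fold higher number from compound 1 to compound 3 (1.04 log units; beyond the scatter) comes from fluoro in place of methyl on an aromatic carbon.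

Compound 4, `O=C(/C=C/c1cccc(Cl)c1Oc1c([N+](=O)[O-])cc(C(F)(F)F)cc1[N+](=O)[O-])c1ccc(F)cc1`, has not yet been measured in this assay. It differs from compound 3 by chloro in place of bromo on an aromatic carbon. This is the same kind of change as that from compound 1 to compound 2, but not the same change: in compound 1 the place is meta to a 2-((4-methylphenyl)carbonyl)ethenyl group, whereas in compound 3 it is meta to a 2-((4-fluorophenyl)carbonyl)ethenyl group. The two cores differ as described above under the difference between compound 1 and compound 3.

Among the measured compounds shown here, because the earlier step of an 18-fold lower number from compound 1 to compound 2 (1.26 log units; beyond the scatter) was large, a lowering of similar direction is expected for compound 4, though the single precedent on a different core leaves the size uncertain, so the expected step is a 12-fold lower number from compound 3 to compound 4 (1.08 log units; beyond the scatter). Compound 4 is therefore estimated to give 0.5 ug/mL in this assay, with a likely range from 0.1 ug/mL to 3 ug/mL.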

Compound 4, half-maximal inhibitory concentration: 5.17 ug/mL
The estimate for compound 4 lay 10-fold (1.01 log units) below the measured number; measured number above the stated range.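

In this assay, chloro in place of bromo on the core of compound 3 gives a 1.2-fold lower number from compound 3 to compound 4 (0.07 log units; within the scatter), so the large step seen on the core of compound 1 did not carry over to this core: the same change on two cores in this assay, an 18-fold lower number (1.26 log units; beyond the scatter) from compound 1 to compound 2 and a 1.2-fold lower number (0.07 log units; within the scatter) from compound 3 to compound 4, 16-fold (1.20 log units) apart, beyond the scatter of two such steps

Fluoro in place of methyl on an aromatic carbon raises the number on both cores, but the size of the step depends on which halogen is present, with a 170-fold higher number from compound 2 to compound 4 (2.24 log units; beyond the scatter) on the chloro core: the same change on two cores in this assay, an 11-fold higher number (1.04 log units; beyond the scatter) from compound 1 to compound 3 and a 170-fold higher number (2.24 log units; beyond the scatter) from compound 2 to compound 4, 16-fold (1.20 log units) apart, beyond the scatter of two such steps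

Together, these four compounds show that the two changes do not add independently in this assay, so the step for one cannot be carried to another core by simple transfer, but they do not show why the steps differ, and the whole gap rests on a single set of four compounds in which compound 2, at 0.03 ug/mL, stands apart.

From the compounds shown here alone, it remains open whether the low number of compound 2 is particular to the pairing of chloro with methyl, or would also appear with an ethyl or a methoxy group in the place of that methyl. Going by these compounds, it is equally open how an iodo group or a nitrile in the place of the halogen would behave on either core.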